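Swapping a piperidinylethyl ether for a cyclopentyl ether

This account rests on a few compounds, and the source may have more. Where it says the series, first, only, none or still open, it means among the compounds named here.

Going by the values given here, in an assay on CHO cells for displacement of a labelled ligand from adenosine receptor A1 (Homo sapiens), read by scintillation counting, with a stated time of 3 h (a higher number here means a weaker inhibitor, a lower number a stronger inhibitor), compound 3 `Cn1c(=O)c2[nH]c(-c3ccc(OCCC4CCNCC4)cc3)nc2n(C)c1=O` gives 1.33 nM, the only outright number among the three measured compounds. Compound 1 `Cn1c(=O)c2[nH]c(Cc3ccc(OCCCn4ccnc4)cc3)nc2n(C)c1=O` gives > 30 nM, which is a limit of the assay and not a number. Compound 2 `Cn1c(=O)c2[nH]c(-c3ccc(OCCCCl)cc3)nc2n(C)c1=O` gives > 10 nM, again a limit rather than a number. Among the compounds with values here, the one step that can be read is an at least 7.5-fold lower number from compound 2 to compound 3 (0.87 log units; beyond the scatter), and within this small set the arrival of the piperidine ring goes with the only measured potency.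

Compound 4 `Cn1c(=O)c2[nH]c(-c3ccc(OC4CCCC4)cc3)nc2n(C)c1=O` differs from compound 3 by cyclopentyl in place of 2-(piperidin-4-yl)ethyl on an oxygen on an aromatic ring. The group that leaves carries a hydrogen-bond donor and a hydrogen-bond acceptor; the cyclopentyl that enters carries neither. Within the data shown here, the only step that bears on this change is an at least 7.5-fold lower number from compound 2 to compound 3 (0.87 log units; beyond the scatter), which ran in the opposite direction by adding the piperidine. Taking that ring away again is therefore expected to push the number up, beyond the scatter. Compound 4 is expected to give 30 nM, in a range from 4 nM to 300 nM, an expected step of a 23-fold higher number from compound 3 to compound 4 (1.35 log units; beyond the scatter).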

Compound 4, inhibition constant: > 30 nM
Compound 4: only a limit was reported; the forecaster's own chance of this, stated with the estimate: 30%; the middle value lies on the limit itself.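

Compound 3 had so far shown only that the piperidine-bearing chain beats a 3-chloropropyl group. In this assay, a second replacement on the same oxygen on an aromatic ring now gives an at least 22-fold higher number from compound 3 to compound 4 (1.35 log units; beyond the scatter), so a carbon-only cyclopentyl ring does not do the work of 2-(piperidin-4-yl)ethyl. The reading for compound 4 is a limit of the assay and not a number, and the step between compound 2 and compound 4 cannot be read, as both stand as limits: the limit of > 30 nM in this assay, at which 2 of the 4 values shown sit.

As far as these compounds go, compound 3 differs from compound 4 in both the ring and the chain, so it stays open whether the ring nitrogen or the two-carbon link counts. A 2-cyclohexylethyl group would keep the chain without the nitrogen, and a piperidin-4-yl group set directly on the oxygen would keep the nitrogen without the chain.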